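The compounds below may be only part of what the source reports. "The series", "measured", "known", "first", "only" and "open" are said of these compounds alone.

For the measured compounds named here, compound 1 `COc1cc(-n2cnc3ccc(-c4ccc(C(C)=O)cc4)cc32)cc(OC)c1OC` is one of three compounds measured in a functional assay on A549 cells (Homo sapiens) for antiproliferative activity, read by MTT assay, with a stated time of 72 h (a lower number here means a stronger inhibitor, a higher number a weaker inhibitor), where compound 1 gives 2510 nM. Among these three numbers compound 1 stands second highest: compound 2 `COc1ccc(-c2ccc3ncn(-c4cc(OC)c(OC)c(OC)c4)c3c2)cc1O` gives 200 nM, a 13-fold lower number from compound 1 to compound 2 (1.10 log units; beyond the scatter), while compound 3 `COc1cc(-n2cnc3ccc(-c4cccc([N+](=O)[O-])c4)cc32)cc(OC)c1OC` gives 5410 nM, a 2.2-fold higher number from compound 1 to compound 3 (0.33 log units; beyond the scatter). Between those two, a 27-fold higher number from compound 2 to compound 3 (1.43 log units; beyond the scatter) shows how far the pendant ring on the shared core can move the number. Compound 4 `COc1cc(-n2cnc3ccc(-c4ccc(C)cc4)cc32)cc(OC)c1OC` differs from compound 1 by methyl in place of acetyl on an aromatic carbon. Going by the values given here, no measured step swaps acetyl for methyl; every measured step replaces the whole pendant ring, so the steps from compound 1 to compound 2 and from compound 1 to compound 3 only set the scale of what a change on that ring has done. Among the compounds with values here, with no step matching this change, the expectation for compound 4 leans on the modest size of the step from compound 1 to compound 3, and a 1.6-fold higher number from compound 1 to compound 4 (0.20 log units; within the scatter) is expected in this assay. Compound 4 is therefore estimated at 4000 nM, between 1500 nM and 12000 nM.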

Compound 4, half-maximal inhibitory concentration: 1940 nM
Compound 4: middle estimate off by 2.1-fold (0.31 log units), on the high side; the range from low to high includes it.
By their numbers in this assay, from the lowest: compound 2; then compounds 4 and 1 (each within the scatter of the next); then compound 3.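

In this assay, for the compounds shown here, this is the first step confined to a group on the pendant ring rather than the whole ring, and methyl in place of acetyl barely registers (a 1.3-fold lower number from compound 1 to compound 4 (0.11 log units; within the scatter)). Losing the carbonyl and the hydrogen-bond acceptor counted in acetyl therefore leaves no mark on this number, and the large gap to the 3-hydroxy-4-methoxyphenyl ring remains (a 9.7-fold higher number from compound 2 to compound 4 (0.99 log units; beyond the scatter)), while the 3-nitrophenyl ring stays modestly apart (a 2.8-fold lower number from compound 3 to compound 4 (0.45 log units; beyond the scatter)). No measurement at hand explains these differences.

On these data alone, whether an amine or a carboxylic acid at this same place would also leave the number unchanged remains open. So does whether the hydroxyl or the methoxy of compound 2 matters more, since those two groups are only seen together.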